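The compounds below may be only part of what the source reports. "The series", "measured", "known", "first", "only" and "open" are said of these compounds alone.

Measured so far:
compound 1, `CCCS(=O)(=O)Nc1ccc(F)c(C(=O)c2n[nH]c3ncc(-c4ccc(C(C)C)cc4)cc23)c1F`: 17%
compound 2, `CCCS(=O)(=O)Nc1ccc(F)c(C(=O)c2n[nH]c3ncc(-c4ccc(OC)cc4Cl)cc23)c1F`: 5.3%

In an assay for binding affinity to dual specificity mitogen-activated protein kinase kinase 4 (Homo sapiens), read by KINOMEscan, tested at 100 nM (a higher number here means a weaker effect of the compound at the concentration tested, a lower number a stronger effect), compound 1 gives 17% and compound 2 gives 5.3%. Compound 2 stands lowest of the two numbers; the nearest, compound 1, lies higher by a number 11.7 percentage points lower from compound 1 to compound 2 (beyond the scatter). Next is compound 3, `CCCS(=O)(=O)Nc1ccc(F)c(C(=O)c2n[nH]c3ncc(-c4ccc([N+](=O)[O-])cc4)cc23)c1F`, to be measured in this assay. The change from compound 2 is 4-nitrophenyl in place of 2-chloro-4-methoxyphenyl on an aromatic carbon. For the measured compounds named here, only one measured step touches the same place: a number 11.7 percentage points lower from compound 1 to compound 2 (beyond the scatter), a modest change. Going by the values given here, compound 3 gives up the 2-chloro-4-methoxyphenyl that went with the lower number, and no measured compound carries 4-nitrophenyl, so any expectation rests on compound 1 alone. A step upward of roughly the size seen in a number 11.7 percentage points lower from compound 1 to compound 2 (beyond the scatter) is expected, with real doubt whether it clears the scatter. Compound 3 is estimated at 15% in this assay, between 4% and 40%. That means an expected step of a number 9.7 percentage points higher from compound 2 to compound 3 (within the scatter).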

Compound 3, a percentage reported as activity, at one concentration (the size of the read-out at that concentration, not a potency): 4.2%
Compound 3: middle estimate off by 10.8 percentage points, on the high side, within the range that was stated.
By their numbers in this assay, from the lowest: compounds 3 and 2 (each within the scatter of the next); then compound 1.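

In this assay the step of a number 1.1 percentage points lower from compound 2 to compound 3 (within the scatter) shows that 4-nitrophenyl and 2-chloro-4-methoxyphenyl cannot be told apart on this aromatic carbon. The second step of a number 12.8 percentage points lower from compound 1 to compound 3 (beyond the scatter) shows, with nitro in place of isopropyl, that reaching the low end of the three numbers does not need the chlorine or the methoxy group of compound 2; among these three compounds only compound 1, with 4-isopropylphenyl, stands apart. No measured evidence bears on why these groups give these numbers.

Open, going by these compounds, is whether 4-isopropylphenyl stands alone or whether other groups at this place, such as unsubstituted phenyl, 4-aminophenyl or 4-carboxyphenyl, also move the number away from that of compound 3. A reading at one concentration also leaves open whether compound 2 and compound 3 would still match at a lower concentration.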